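This account rests on a few compounds, and the source may have more. Where it says the series, first, only, none or still open, it means among the compounds named here.

Compound 1 `CCCC(=O)N1CC2CC(C1)N2` — 14 nM
Compound 2 `O=C(C1CC=CC1)N1CC2CC(C1)N2` — 51 nM
Compound 3 `O=C(CC1C=CCC1)N1CC2CC(C1)N2` — 53 nM

Three amides built on a shared core were tested in an assay on SH-EP1 cells for displacement of a labelled ligand from Neuronal acetylcholine receptor; alpha4/beta2 (Homo sapiens), read by scintillation counting; on this read-out lower numbers stand for stronger inhibition and higher numbers for weaker inhibition. Compound 1 gives 14 nM, the lowest of the three numbers. Compound 2 gives 51 nM and compound 3 gives 53 nM, each beyond the scatter from compound 1. Compound 4 `O=C([C@H]1C[C@H]1F)N1CC2CC(C1)N2` has not yet been measured; it differs from compound 1 in one place: 2-fluorocyclopropyl in place of propyl on a carbonyl carbon. Among the compounds with values here, the one measured step that bears on this is a 3.8-fold higher number from compound 1 to compound 3 (0.58 log units; beyond the scatter), in which a ring entered in place of part of the chain. Compound 2, the other ring-bearing amide, shows a gap of similar size from compound 1. A ring entering in compound 4 is therefore expected to raise the number modestly, a 2.5-fold higher number from compound 1 to compound 4 (0.40 log units; beyond the scatter). Compound 4 is estimated at 35 nM, within a range of 12 nM to 110 nM.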

Compound 4, inhibition constant: 1.1 nM
Compound 4: middle estimate off by 32-fold (1.50 log units), on the high side; measured number outside the range, below it.
By their numbers in this assay, from the lowest: compound 4; then compound 1; then compounds 2 and 3 (each within the scatter of the next).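

On the carbonyl carbon, replacing a chain with a ring can lower the number sharply, not only raise it: 2-fluorocyclopropyl in place of propyl gives a 13-fold lower number from compound 1 to compound 4 (1.10 log units; beyond the scatter). The kind of ring matters too, as compound 2, with a larger ring on the carbonyl carbon, gives (51 nM). Nothing shown here explains why the number falls so far.

From the compounds shown here alone, whether the fluorine, the three-membered ring or the two defined stereocentres drive the change stays open. Plain cyclopropyl and the mirror-image 2-fluorocyclopropyl would help separate these.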